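A few compounds are considered here, and "the series" means these few. Any claim that something is new, unique, unknown or untested is made for them only; others in the source may bear on it.

Measured compounds:
- compound 1 `CNc1nc(-n2cc(-c3ccccc3)nn2)nc2c1ncn2[C@@H]1O[C@H](CO)[C@@H](O)[C@H]1O` with 14.9 nM
- compound 2 `CCNC(=O)[C@H]1O[C@@H](n2cnc3c(NC)nc(-n4cc(CC5CCCC5)nn4)nc32)[C@H](O)[C@@H]1O` with 11.5 nM
- compound 3 `COc1ccc(Cl)c(CNc2nc(-n3cc(CC4CCCC4)nn3)nc3c2ncn3[C@@H]2O[C@H](CO)[C@@H](O)[C@H]2O)c1` with 18 nM

In an assay on CHO cells for displacement of a labelled ligand from adenosine receptor A3 (Homo sapiens) (on this read-out lower numbers stand for stronger inhibition and higher numbers for weaker inhibition), compound 3 stands at the highest of the three numbers, but the three values lie close together: compound 1 is nearest and compound 2 furthest, and both gaps fall within the scatter of repeated measurements, so no order among compounds 1, 2 and 3 can be read from them.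

The step to compound 4 `CNc1nc(-n2cc(CC3CCCC3)nn2)nc2c1ncn2[C@@H]1O[C@H](CO)[C@@H](O)[C@H]1O` is a single cut on the amine that hangs from the shared core: hydrogen in place of 2-chloro-5-methoxyphenyl on a saturated chain carbon bound to a nitrogen on an aromatic ring. Compound 4 therefore carries the same methylamino and the same cyclopentylmethyl-bearing triazole found across the other compounds, and differs from compound 1 only in the group attached to the triazole. For the measured compounds named here, no pair of measured compounds differs in exactly this way, so the step has no measured precedent here. Because compounds 1, 2 and 3 all sit within the scatter of one another despite their varied amine and sugar substituents, the removal of the 2-chloro-5-methoxyphenyl is expected to produce no step beyond the scatter in this assay. The expected step from compound 3 to compound 4 is a 1.3-fold lower number from compound 3 to compound 4 (0.11 log units; within the scatter). Compound 4 is estimated at 14 nM in this assay, with a plausible range from 5 nM to 40 nM.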

Compound 4, inhibition constant: 1.3 nM
The estimate for compound 4 lay 11-fold (1.03 log units) above the measured number; the whole stated range lies above it.
By their numbers in this assay, from the lowest: compound 4; then compounds 2, 1 and 3 (each within the scatter of the next).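

In this assay, methylamino in place of (2-chloro-5-methoxybenzyl)amino gives a 14-fold lower number from compound 3 to compound 4 (1.14 log units; beyond the scatter) on the amine of the shared core, so with the cyclopentylmethyl-bearing triazole and the hydroxymethyl in place, this position is far from indifferent to the group it carries. The two other single changes also reach beyond the scatter: hydroxymethyl in place of ethylcarbamoyl on a saturated ring carbon gives an 8.8-fold lower number from compound 2 to compound 4 (0.95 log units; beyond the scatter) and cyclopentylmethyl in place of phenyl on an aromatic carbon gives an 11-fold lower number from compound 1 to compound 4 (1.06 log units; beyond the scatter) in the same assay. The closeness of compounds 1, 2 and 3 therefore said nothing about any one place on its own, since each of them stands apart from compound 4 by a single change.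

As far as these compounds go, it remains open whether a plain amino or an ethylamino group on the core would match methylamino, and whether an unsubstituted benzyl would behave like 2-chloro-5-methoxybenzyl. From the compounds shown here alone, it also remains open whether the step on this amine would keep its size with phenyl on the triazole or with ethylcarbamoyl on the sugar. No measurement in hand accounts for any of these steps.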